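This account rests on a few compounds, and the source may have more. Where it says the series, first, only, none or still open, it means among the compounds named here.

Working notes on the series. Compound 1 `Cc1ccccc1-n1nc(C)c2c1NC(=O)[C@H](C)S[C@@H]2c1ccc(Oc2ccccc2)cc1` in an assay on isolated protein for agonist activity at Bile acid receptor (Homo sapiens), read by AlphaScreen, with a stated time of 30 min (a lower number here means that less compound is needed, a higher number that more compound is needed for the effect), gives 1300 nM. Compound 2 `Cc1ccccc1-n1nc(C)c2c1NC(=O)[C@H](C)S[C@@H]2c1ccc(-c2ccoc2)cc1` gives 3500 nM, and compound 3 `COc1ccc(Oc2ccc([C@H]3S[C@@H](C)C(=O)Nc4c3c(C)nn4-c3ccccc3C)cc2)cc1` gives 2200 nM. Compound 3 thus holds the second highest of the three numbers; its steps to both neighbours, a 1.7-fold higher number from compound 1 to compound 3 (0.23 log units; within the scatter) and a 1.6-fold lower number from compound 2 to compound 3 (0.20 log units; within the scatter), lie within the scatter, whereas a 2.7-fold higher number from compound 1 to compound 2 (0.43 log units; beyond the scatter) lies beyond it. Compound 4 `COc1ccccc1Oc1ccc([C@H]2S[C@@H](C)C(=O)Nc3c2c(C)nn3-c2ccccc2C)cc1` has the same atoms as compound 3 joined differently: 2-methoxyphenyl in place of 4-methoxyphenyl on an oxygen on an aromatic ring. Among the compounds with values here, the only measured step that touches this part of the molecule, a 1.7-fold higher number from compound 1 to compound 3 (0.23 log units; within the scatter), was within the scatter, so in this assay no step beyond the scatter is expected in either direction. Compound 4 is estimated at 2000 nM, within 700 nM to 6000 nM. The expected step is accordingly a 1.1-fold lower number from compound 3 to compound 4 (0.04 log units; within the scatter).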

Compound 4, half-maximal effective concentration: 1700 nM
For compound 4 the middle estimate is 1.2-fold (0.07 log units) above the measured one, and the stated range covers the measured number.
By their numbers in this assay, from the lowest: compounds 1, 4, 3 and 2 (each within the scatter of the next, the first and the last beyond it).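

In this assay, moving the methoxy from 4-methoxyphenyl to 2-methoxyphenyl on this oxygen gives a 1.3-fold lower number from compound 3 to compound 4 (0.11 log units; within the scatter), and the 2-methoxyphenoxy group against plain phenoxy gives a 1.3-fold higher number from compound 1 to compound 4 (0.12 log units; within the scatter), so neither step separates these compounds. Against furan-3-yl, 2-methoxyphenoxy gives a 2.1-fold lower number from compound 2 to compound 4 (0.31 log units; beyond the scatter), a modest step, whereas 4-methoxyphenoxy stayed within the scatter of furan-3-yl. No supporting data bear on these steps. As far as these compounds go, what an amine, a carboxylic acid or a longer chain in place of the methoxy would give remains open.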